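Methoxy Added to Two Different Cores

This account rests on a few compounds, and the source may have more. Where it says the series, first, only, none or still open, it means among the compounds named here.

Compound 1 `O=C(/C=C/c1ccccc1-c1ccc(F)cc1)c1cccc(O)c1` and compound 2 `COc1ccc(C(=O)/C=C/c2ccccc2-c2ccc(F)cc2)cc1O` share one core, while compound 3 `COc1ccc(CNC(=O)c2ccccc2-c2ccc(F)cc2)cc1` and compound 4 `COc1ccc(CNC(=O)c2ccccc2-c2ccc(F)cc2)cc1OC` share another; the difference between the two cores is not broken down here. In a functional assay on SW480 cells (Homo sapiens) for antiproliferative activity, read by sulforhodamine B assay, with a stated time of 48 h (on this read-out higher numbers stand for weaker inhibition and lower numbers for stronger inhibition), compound 1 gives 8700 nM. Compound 2 gives 340 nM in this assay, a step of a 26-fold lower number from compound 1 to compound 2 (1.41 log units; beyond the scatter) brought about by methoxy in place of hydrogen on an aromatic carbon. For compound 3 only a limit is known in this assay, namely > 50000 nM, which is the limit of > 50000 nM in this assay, at which 1 of the 3 values shown sits. Compound 4 differs from compound 3 by methoxy in place of hydrogen on an aromatic carbon. Among the measured compounds shown here, this is the same kind of change as the one from compound 1 to compound 2, though not the same: in compound 2 the entering group sits ortho to a hydroxy group and para to a large group, whereas in compound 4 it sits ortho to a methoxy group and meta to a large group. Since compound 3 is known only as a limit, the step is expected to be a step that the limit leaves unreadable from compound 3 to compound 4, much smaller than the measured one. Compound 4 is therefore estimated at 60000 nM in this assay, quite possibly again only a limit.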

Compound 4, half-maximal inhibitory concentration: > 50000 nM
Compound 4: only a limit was reported; the forecaster's own chance of this, stated with the estimate: 70%; the middle value does not contradict the limit.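

No step can be read from compound 3 to compound 4 in this assay, since each of the two is known only as a limit: the limit of > 50000 nM in this assay, at which 2 of the 4 values shown sit.

The compounds shown leave open whether methoxy in place of hydrogen on an aromatic carbon changes the number on the shared core of compound 3 and compound 4.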